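Isopropyl Swapped for Dimethylmorpholine on a Shared Core

A few compounds are considered here, and "the series" means these few. Any claim that something is new, unique, unknown or untested is made for them only; others in the source may bear on it.

Compound 1, `CC(C)c1c(NC(=O)Nc2ccnc(C(F)(F)F)c2)cnc2cc(Cl)nn12`: in an ADME assay on microsomes from liver (Rattus norvegicus) for metabolic stability (a lower number here means slower removal, a higher number faster removal of the compound), compound 1 gives < 25 mL.min-1.g-1, which is a limit of the assay rather than a measured number.
Compound 2, `CO[C@H](C)c1c(NC(=O)Nc2cnc(-n3nccn3)c(Cl)c2)cnc2cc(Cl)nn12`: in this assay compound 2 gives < 25 mL.min-1.g-1, again a limit.
Compound 3, `O=C(Nc1cnc(-n2nccn2)c(Cl)c1)Nc1cnc2cc(Cl)nn2c1C1CCOCC1`: in this assay compound 3 gives 25.5 mL.min-1.g-1.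

Compound 1 therefore stands at the limit of what this assay reports, and compound 2 sits there too, while compound 3 gives a number close to that limit, as the limit of < 25 mL.min-1.g-1 in this assay, at which 2 of the 3 values shown sit, shows. The only measured step among these compounds is an at least 1.0-fold higher number from compound 2 to compound 3 (0.00 log units; that floor lies within the scatter), which lies within the scatter and concerns a different exchange on the shared core. Compound 4, `C[C@H]1COC[C@H](C)N1c1c(NC(=O)Nc2ccnc(C(F)(F)F)c2)cnc2cc(Cl)nn12`, differs from compound 1 by 3,5-dimethylmorpholin-4-yl in place of isopropyl on an aromatic carbon. Among the compounds with values here, no measured step exchanges isopropyl for a ring, so nothing in these results points to a step beyond the scatter in this assay for compound 4. The estimate for compound 4 is 25 mL.min-1.g-1, with a range from 10 mL.min-1.g-1 to 60 mL.min-1.g-1. The step this estimate implies, a number no lower from compound 1 to compound 4 (the limit leaves the size open), is expected to stay within the scatter.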

Compound 4, intrinsic clearance in microsomes: 42 mL.min-1.g-1
Estimate against measurement, compound 4: 1.7-fold (0.23 log units) below, and the stated range covers the measured number.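

In this assay, on the aromatic carbon next to the ring nitrogen, putting 3,5-dimethylmorpholin-4-yl in place of isopropyl gives an at least 1.6-fold higher number from compound 1 to compound 4 (0.22 log units; that floor lies within the scatter). Compound 4 reads as a measured number rather than a limit, so with this ring at this position the assay returns a value that can be compared with later compounds. How large the step really is cannot be said, and its floor alone does not clear the scatter, because compound 1 carries only a limit: the limit of < 25 mL.min-1.g-1 in this assay, at which 2 of the 4 values shown sit.

From the compounds shown here alone, whether the higher number, if real, goes with the ring, its oxygen or its two methyl groups remains open. Plain morpholin-4-yl, without the methyl groups, and piperidin-1-yl, without the ring oxygen, would tell these parts apart, and a different arrangement of the two stereocentres would test their role.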